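Series notes: from compound 3 to compound 4

This account rests on a few compounds, and the source may have more. Where it says the series, first, only, none or still open, it means among the compounds named here.

Measured compounds:
compound 1 `CN1CCN(c2ccc(C3=NNC(c4ccc(N(C)C)cc4)C3)cc2)CC1`: 11.4%
compound 2 `COC(=O)CC(=O)N1N=C(c2ccc(N3CCN(C)CC3)cc2)CC1c1ccc(N(C)C)cc1`: -0.4%
compound 3 `Cc1ccc(C(=O)N2N=C(c3ccc(N4CCN(C)CC4)cc3)CC2c2ccc(N(C)C)cc2)cc1`: -0.7%

In a functional assay on MDA-MB-231 cells (Homo sapiens) for inhibition, read by sulforhodamine B assay, tested at 10 uM (on this read-out lower numbers stand for less inhibition and higher numbers for more inhibition at the one concentration tested (going by the name of the read-out)), compound 3 stands lowest of the three numbers, though its gap to compound 2, a number 0.3 percentage points lower from compound 2 to compound 3 (within the scatter), is within the scatter, while its gap to compound 1, a number 12.1 percentage points lower from compound 1 to compound 3 (beyond the scatter), is beyond it. Compound 4 `CN1CCN(c2ccc(C3=NN(C(=O)c4ccc(F)cc4)C(c4ccc(N(C)C)cc4)C3)cc2)CC1` differs from compound 3 by fluoro in place of methyl on an aromatic carbon. Among the compounds with values here, no measured step changes a substituent on that aromatic ring. Within the data shown here, the steps that bear on it are a number 11.8 percentage points lower from compound 1 to compound 2 (beyond the scatter) and a number 12.1 percentage points lower from compound 1 to compound 3 (beyond the scatter), which show that carbonyl substitution on the ring amine nitrogen lowers inhibition, and a number 0.3 percentage points lower from compound 2 to compound 3 (within the scatter), which shows that the group on that carbonyl barely matters. For compound 4 the expected step is therefore a number 0.7 percentage points higher from compound 3 to compound 4 (within the scatter), none beyond the scatter. Compound 4 is estimated at 0%, with a range from -8% to 8%.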

Compound 4, a percentage reported as inhibition, at one concentration (the size of the read-out at that concentration, not a potency): 3.5%
The estimate for compound 4 lay 3.5 percentage points below the measured number; the range from low to high includes it.
By their numbers in this assay, from the lowest: compounds 3, 2, 4 and 1 (each within the scatter of the next, the first and the last beyond it).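

In this assay, 4-fluorophenyl in place of 4-methylphenyl gives a number 4.2 percentage points higher from compound 3 to compound 4 (within the scatter) and so resolves no effect of this first change on that aromatic ring. The (4-fluorophenyl)carbonyl group is also not separated from the ester-bearing acyl group, with a number 3.9 percentage points higher from compound 2 to compound 4 (within the scatter) as the step. Unlike the other two acylations of the ring nitrogen, adding (4-fluorophenyl)carbonyl gives a number 7.9 percentage points lower from compound 1 to compound 4 (within the scatter) and stays within the scatter, so the loss seen with the other acyl groups is not established here. On these data alone, whether an amine or a carboxylic acid on this aromatic ring would raise inhibition remains open. No measured evidence accounts for these numbers.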